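The source may report more compounds than this note shows. Statements on the series, on what has been measured and on what is new or still open speak of the compounds shown alone.

Compound 1 `COCCOc1cc2ncnc(-n3nc(-c4ccccn4)nc3N)c2cc1OCCOC`: 12.9 mL/min/kg
Compound 2 `COCCOc1cc2c(-n3nc(-c4ccccn4)nc3N)ncnc2cc1OC`: < 5.2 mL/min/kg

In an ADME assay on liver for metabolic stability, with Liver microsome (Homo sapiens) as the target, read by HPLC, using microsomes, with a stated time of 4 h (a higher number here means faster removal of the compound, a lower number slower removal), compound 2 stands at < 5.2 mL/min/kg, which is a limit of the assay and not a number. Compound 3 `COc1cc2ncnc(-n3nc(-c4ccccn4)nc3N)c2cc1OCCCNC(=O)OC(C)C` carries one change from it: ((isopropoxycarbonyl)amino)methyl in place of methoxy on a saturated chain carbon, two bonds along the chain from an oxygen on an aromatic ring. Here ((isopropoxycarbonyl)amino)methyl stands in place of methoxy on a saturated chain carbon, two bonds along the chain from an oxygen on an aromatic ring. Within the data shown here, the only measured step on such a chain is an at least 2.4-fold lower number from compound 1 to compound 2 (0.39 log units; beyond the scatter), which came with hydrogen in place of methoxymethyl. Compound 3 goes the other way, with a larger group entering, so a rise of similar size, beyond the scatter, is expected in this assay. The expected step is an at least 2.1-fold higher number from compound 2 to compound 3 (0.32 log units; beyond the scatter). The estimate for compound 3 is 11 mL/min/kg, with an expected range from 5.5 mL/min/kg to 20 mL/min/kg.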

Compound 3, clearance: 18.8 mL/min/kg
Compound 3: the middle estimate sits 1.7-fold (0.23 log units) below what was measured; low and high end bracket the measured number.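

In this assay, the group at this place now shows a rise as well as a fall: ((isopropoxycarbonyl)amino)methyl in place of methoxy gives an at least 3.6-fold higher number from compound 2 to compound 3 (0.55 log units; beyond the scatter). Among these compounds, the only earlier step here, with hydrogen in place of methoxymethyl, ran the other way, so the number moves in both directions with what sits on this saturated chain carbon. The true size of the step stays unknown, since compound 2 rests on a limit of the assay: the limit of < 5.2 mL/min/kg in this assay, at which 1 of the 3 values shown sits.

Going by these compounds, whether the rise goes with the added chain length or with the isopropoxycarbonyl part stays open. An amine or a plain alkyl chain at this place would tell these apart.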